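The compounds below may be only part of what the source reports. "The series", "measured", "known", "first", "only" and "open" are said of these compounds alone.

Of the compounds shown here, two with a shared core have been tested so far in a functional assay on HeLa cells (Homo sapiens) for inhibition, read by MTT assay, with a stated time of 48 h; a higher number here means a weaker inhibitor of growth, a lower number a stronger inhibitor of growth. Compound 1 `COc1ccc(C2=NN(C(=O)c3ccc(OC)nc3)C(c3cn(C)c4ccc(OC)cc34)C2)cc1` gives 180 nM, and compound 2 `COc1cccc(C2=NN(C(=O)c3cccnc3)C(c3cn(C)c4ccc(OC)cc34)C2)c1` gives 1270 nM. That is the higher of the two numbers, so compound 2 is the weaker growth inhibitor here, by a margin beyond the usual scatter. These two compounds differ in more than one place, so their gap cannot be pinned on any single group.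

Compound 3 `COc1cccc(C2=NN(C(=O)c3ccc(OC)nc3)C(c3cn(C)c4ccc(OC)cc34)C2)c1` comes from compound 2 by one change: methoxy in place of hydrogen on an aromatic carbon. Methoxy takes the place of hydrogen on an aromatic carbon, turning pyridin-3-yl into 6-methoxypyridin-3-yl. That group is already present in compound 1, the stronger of the pair at 180 nM, so a move towards a lower number is expected. For the measured compounds named here, it is expected to be smaller than the whole gap between the two measured compounds, and no measured step exists to fix its size. The expected change is a 2.8-fold lower number from compound 2 to compound 3 (0.45 log units; beyond the scatter). In this assay the estimated value for compound 3 is 450 nM, with a likely range from 150 nM to 1300 nM.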

Compound 3, concentration for 50% growth inhibition: 340 nM
Compound 3: the middle estimate sits 1.3-fold (0.12 log units) above what was measured, and the stated range covers the measured number.
By their numbers in this assay, from the lowest: compounds 1 and 3 (each within the scatter of the next); then compound 2.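

In this assay, placing methoxy on the aromatic carbon next to the ring nitrogen, which turns pyridin-3-yl into 6-methoxypyridin-3-yl, gives a 3.7-fold lower number from compound 2 to compound 3 (0.57 log units; beyond the scatter). For the compounds shown here, this is the first change here made in one place alone, so a size can now be attached to this group at this position, which the first two compounds could not provide. With 6-methoxypyridin-3-yl held fixed, 3-methoxyphenyl in place of 4-methoxyphenyl gives a 1.9-fold higher number from compound 1 to compound 3 (0.28 log units; within the scatter), so this second swap cannot be told apart from the normal spread of repeated measurements. The data shown offer no measurement that explains either step.

As far as these compounds go, whether the step belongs to methoxy in particular stays open, as a chlorine atom, an amine or the longer ethoxy group at the same place could give a smaller, similar or larger step. From the compounds shown here alone, it also stays open whether adding methoxy to pyridin-3-yl would give a step of the same size in a compound carrying 4-methoxyphenyl rather than 3-methoxyphenyl.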